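Ring contraction on the amine of compound 1

This account rests on a few compounds, and the source may have more. Where it says the series, first, only, none or still open, it means among the compounds named here.

Measured compounds:
compound 1 `O=C1C(N2CCCCC2)=NN(c2ccc(Cl)cc2)CN1c1ccccc1Cl`: 5
compound 2 `O=C1C(N2CCCCC2)=NN(c2ccccc2)CN1c1ccccc1Cl`: 4.6

The two measured compounds were run in a physicochemical assay for lipophilicity, read by HPLC, measured as octanol-water partition; a lower number here means a more polar compound, a higher number a more lipophilic compound. Compound 1 `O=C1C(N2CCCCC2)=NN(c2ccc(Cl)cc2)CN1c1ccccc1Cl` gives 5 and stands highest of the two numbers; its nearest neighbour is compound 2 `O=C1C(N2CCCCC2)=NN(c2ccccc2)CN1c1ccccc1Cl`, which gives 4.6. Within the data shown here, the only measured step is a number 0.40 log units lower from compound 1 to compound 2 (beyond the scatter), hydrogen in place of chloro on an aromatic carbon.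

Compound 3 `O=C1C(N2CCCC2)=NN(c2ccc(Cl)cc2)CN1c1ccccc1Cl` has not yet been measured. It differs from compound 1 in one place: pyrrolidin-1-yl in place of piperidin-1-yl on a carbon with a double bond to nitrogen. The six-membered non-aromatic ring with one hetero atom leaves and a five-membered non-aromatic ring with one hetero atom enters, on the carbon with a double bond to nitrogen of the shared core.

Among the measured compounds shown here, no measured step touches this part of the structure; the step from compound 1 to compound 2 concerns a chloro group elsewhere and does not bear on it directly. For the measured compounds named here, with no step of the same kind in hand, the expectation rests on the change itself, which removes part of the ring, and a small downward movement in this assay is expected, possibly within the scatter. For compound 3 the estimate is 4.6, with a range from 4.2 to 5, which is expected to mean a step of a number 0.40 log units lower from compound 1 to compound 3 (beyond the scatter).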

Compound 3, partition coefficient: 4.6
Estimate against measurement, compound 3: no gap at the digits printed; the measured number falls inside the stated range.
By their numbers in this assay, from the lowest: compounds 2 and 3 (each within the scatter of the next); then compound 1.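

In this assay, among these compounds, the change from piperidin-1-yl to pyrrolidin-1-yl gives a number 0.40 log units lower from compound 1 to compound 3 (beyond the scatter) and is the first measured step on the carbon with a double bond to nitrogen of the shared core. Among the compounds shown here, this position therefore responds to a change in ring size, which the earlier compounds could not show, as their only step concerned a chloro group on an aromatic carbon. The data hold nothing that accounts for this movement.

The compounds shown leave open how far this position follows ring size or ring content: azepan-1-yl, with a larger ring, morpholin-4-yl, with an oxygen in the ring, and the open-chain diethylamino group would each test that on the same core. They also leave open whether pyrrolidin-1-yl in place of piperidin-1-yl would give a step of similar size on compound 2, and so whether the changes at the two places add up in this assay when they are combined in a single compound.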